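Microsomal half-life notes: from compound 2 toward compound 4

This account rests on a few compounds, and the source may have more. Where it says the series, first, only, none or still open, it means among the compounds named here.

Measured so far:
- compound 1 `Fc1ccc(N2CCN(CCCc3c[nH]c4ccc(F)cc34)CC2)c(-c2cn[nH]c2)c1`: 0.12 h
- compound 2 `Cn1cc(-c2cc(F)ccc2N2CCN(CCCc3c[nH]c4ccc(F)cc34)CC2)cn1`: 0.158 h
- compound 3 `Fc1ccc2[nH]cc(CCCCN3CCN(c4nsc5ccccc45)CC3)c2c1`: 0.0567 h

In an ADME assay on microsomes from liver (Rattus norvegicus) for metabolic stability, read by LC-MS, using NADPH, with a stated time of 90 min, tested at 1 uM (on this read-out lower numbers stand for a shorter-lived compound and higher numbers for a longer-lived compound), compound 2 gives 0.158 h and stands highest of the three numbers. Among the measured compounds shown here, its nearest neighbour is compound 1, and the only single-point step on record, a 1.3-fold higher number from compound 1 to compound 2 (0.12 log units; within the scatter), lies within the scatter, so compound 1 and compound 2 cannot be ordered on this read-out. Compound 3, built on a different core, sits furthest away, and its gap to compound 2 is beyond the scatter.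

Compound 4 `Fc1ccc(N2CCN(CCCc3c[nH]c4ccc(F)cc34)CC2)c(-c2cncnc2)c1` differs from compound 2 as follows: pyrimidin-5-yl in place of 1-methyl-1H-pyrazol-4-yl on an aromatic carbon. For the measured compounds named here, no measured step bears directly on the exchange of one small heteroaromatic ring for another at this position. Going by the values given here, the one related step, a 1.3-fold higher number from compound 1 to compound 2 (0.12 log units; within the scatter), altered only the substituent on the aromatic nitrogen of the ring that now leaves and moved the number by less than the scatter. Nothing in the measured set points to a large shift in either direction for a change of this kind, so the expectation for this assay is a step no larger than the scatter, with the direction left open.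

The half-life of compound 4 in this assay is therefore estimated at 0.12 h, with a range from 0.06 h to 0.25 h, which corresponds to an expected step of a 1.3-fold lower number from compound 2 to compound 4 (0.12 log units; within the scatter).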

Compound 4, half-life: 0.11 h
For compound 4 the middle estimate is 1.1-fold (0.04 log units) above the measured one; the range from low to high includes it.
By their numbers in this assay, from the lowest: compounds 3, 4, 1 and 2 (each within the scatter of the next, the first and the last beyond it).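

In this assay, replacing the ring itself on this aromatic carbon, ortho to a large group, gives a 1.4-fold lower number from compound 2 to compound 4 (0.16 log units; within the scatter), and the matching exchange from 1H-pyrazol-4-yl gives a 1.1-fold lower number from compound 1 to compound 4 (0.04 log units; within the scatter). The earlier step changed only the substituent on the aromatic nitrogen of a retained ring, whereas these two steps replace a five-membered aromatic ring with a six-membered one, and neither separates the pair on this read-out. Across the three compounds that differ only at this carbon, the exchanges shown therefore leave the half-life within the scatter, although no evidence here accounts for this flat reading.

Still open is whether a group of another kind on this aromatic carbon, such as a primary amine or a carboxylic acid, would give a step beyond the scatter, as the substituents shown here are limited to 1H-pyrazol-4-yl, 1-methyl-1H-pyrazol-4-yl and pyrimidin-5-yl. Also open, from the compounds shown here alone, is whether the exchange of 1-methyl-1H-pyrazol-4-yl for pyrimidin-5-yl would read the same way on an otherwise matched compound with a longer chain.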